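The source may report more compounds than this note shows. Statements on the series, on what has been measured and on what is new or still open speak of the compounds shown alone.

Measured so far:
Compound 1 `Cc1ccc(OCc2nnc(S)n2N2C(=O)CSC2c2c[nH]nc2-c2ccc(F)cc2)cc1` — > 100 ug/mL
Compound 2 `COc1ccc(-c2n[nH]cc2C2SCC(=O)N2n2c(S)nnc2COc2ccccc2C)cc1` — 29 ug/mL
Compound 3 `COc1ccc(-c2n[nH]cc2C2SCC(=O)N2n2c(S)nnc2COc2ccccc2)cc1` — 85 ug/mL

In a functional assay on MCF7 cells (Homo sapiens) for inhibition, read by MTT assay, with a stated time of 24 h (on this read-out lower numbers stand for stronger inhibition and higher numbers for weaker inhibition), compound 3 stands highest of the two numbers shown; its nearest neighbour is compound 2, with a 2.9-fold higher number from compound 2 to compound 3 (0.47 log units; beyond the scatter). Compound 1, which carries a methyl at the same place as the new compound but differs elsewhere, gives only a limit, (the limit of > 100 ug/mL in this assay, at which 1 of the 3 values shown sits). Compound 4 `COc1ccc(-c2n[nH]cc2C2SCC(=O)N2n2c(S)nnc2COc2ccc(C)cc2)cc1` differs from compound 3 by methyl in place of hydrogen on an aromatic carbon. Among the compounds with values here, the one measured step, the methyl removal between compound 2 and compound 3, sat at a different place on the same ring, so it bears only loosely on this change. A modest lowering is therefore expected, a 1.5-fold lower number from compound 3 to compound 4 (0.19 log units; within the scatter), and compound 4 is estimated at 55 ug/mL, with a range from 22 ug/mL to 140 ug/mL.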

Compound 4, half-maximal inhibitory concentration: 78 ug/mL
For compound 4 the middle estimate is 1.4-fold (0.15 log units) below the measured one; low and high end bracket the measured number.
By their numbers in this assay, from the lowest: compound 2; then compounds 4 and 3 (each within the scatter of the next). At a limit, above all of these: compound 1.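

In this assay, methyl in place of hydrogen on an aromatic carbon gives a 1.1-fold lower number from compound 3 to compound 4 (0.04 log units; within the scatter), so a methyl at this place makes no readable difference. With 4-methylphenyl in place of 2-methylphenyl the result is a 2.7-fold higher number from compound 2 to compound 4 (0.43 log units; beyond the scatter), which shows that where the methyl sits on this ring counts, and only the 2-methylphenyl form stands apart from the plain phenyl. With methoxy in place of fluoro on an aromatic carbon the result is an at least 1.2-fold lower number from compound 1 to compound 4 (0.10 log units; that floor lies within the scatter), and this step cannot be read any further. Compound 1 gives only a limit: the limit of > 100 ug/mL in this assay, at which 1 of the 4 values shown sits.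

Going by these compounds, whether this place tolerates only small groups stays open. A chloro, an amine or a carboxylic acid here might behave quite differently from methyl.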